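From 4-fluorophenyl to 3,4-difluorophenyl: one added fluoro

This account rests on a few compounds, and the source may have more. Where it says the series, first, only, none or still open, it means among the compounds named here.

Measured in a functional assay on Jurkat cells (Homo sapiens) for inhibition, read by MTT assay, with a stated time of 72 h; a higher number here means a weaker inhibitor, a lower number a stronger inhibitor:
- compound 1 `COc1cccc(/C=C/C(=O)Nc2cc(OC)c(OC)c(OC)c2)c1`: 12500 nM
- compound 2 `C=C(Br)C(=O)Nc1cccc(/C=C/C(=O)Nc2cccc3ccccc23)c1`: 680 nM
- compound 3 `C=C(Br)C(=O)Nc1cccc(/C=C/C(=O)Nc2ccc(F)cc2)c1`: 6200 nM

In this assay, compound 3 gives 6200 nM, which lies within the scatter of compound 1 at 12500 nM. Compound 2 gives a lower number, 680 nM, and its gap to compound 3 lies beyond the scatter.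

Compound 4 `C=C(Br)C(=O)Nc1cccc(/C=C/C(=O)Nc2ccc(F)c(F)c2)c1` is not yet measured. It differs from compound 3 by fluoro in place of hydrogen on an aromatic carbon, ortho to a fluoro group, so that 4-fluorophenyl becomes 3,4-difluorophenyl: fluoro in place of hydrogen on an aromatic carbon. Among the measured compounds shown here, no measured pair in this small set differs in one place only, so the data give no direct guide to this change. For so small a change, no step beyond the scatter is expected in this assay, with at most a slight lean towards a lower number. The expected step is a 1.2-fold lower number from compound 3 to compound 4 (0.09 log units; within the scatter). For compound 4 the estimated value is 5000 nM, with an expected range of 2000 nM to 12000 nM.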

Compound 4, half-maximal inhibitory concentration: 550 nM
The estimate for compound 4 lay 9.1-fold (0.96 log units) above the measured number, outside the stated range (below it).
By their numbers in this assay, from the lowest: compounds 4 and 2 (each within the scatter of the next); then compounds 3 and 1 (each within the scatter of the next).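

In this assay, the change from 4-fluorophenyl to 3,4-difluorophenyl gives an 11-fold lower number from compound 3 to compound 4 (1.05 log units; beyond the scatter), a large step that lies beyond the scatter. Among the compounds shown here, this is the first comparison here between compounds that differ in one place only, and it shows that this aromatic carbon, ortho to a fluoro group, is far from indifferent to substitution: one added heavy atom, with no hydrogen-bond donor, no hydrogen-bond acceptor and no net charge, is enough to move the number this far. Nothing available explains why this single fluoro has so large an effect.

The compounds shown leave open whether the step is particular to fluoro or would also follow from a chloro or an amine at this place. They also leave open whether it depends on the neighbouring fluoro group remaining in place.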